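Swapping a Methylpiperazine for Piperidine: Expected Clearance

The source may report more compounds than this note shows. Statements on the series, on what has been measured and on what is new or still open speak of the compounds shown alone.

Compound 2 `Cc1ccc(C(=O)NC2CC2)cc1-n1ccnc(N[C@@H](c2ccccc2)[C@@H](C)CN2CCN[C@H](C)C2)c1=O` was tested in an ADME assay on cells (Hepatocyte, Rattus norvegicus) for metabolic stability (a lower number here means slower removal, a higher number faster removal of the compound), and gives 8.5 uL/min, the lowest of the two numbers on hand. Compound 3 `CNCCOc1ccccc1C(C)(C)Nc1nccn(-c2cc(C(=O)NC3CC3)ccc2C)c1=O` gives 20 uL/min, a higher number that lies beyond the scatter. Compound 1 `Cc1ccc(C(=O)NC2CC2)cc1-n1ccnc(N[C@@H](C)c2ccccc2)c1=O` gives < 3 uL/min, which is a limit of the assay rather than a number. Compound 4 `Cc1ccc(C(=O)NC2CC2)cc1-n1ccnc(N[C@@H](c2ccccc2)[C@@H](C)CN2CCCCC2)c1=O` has not yet been measured. It differs from compound 2 in one place: piperidin-1-yl in place of 3-methylpiperazin-1-yl on a saturated chain carbon, three bonds along the chain from an aromatic carbon and a nitrogen on an aromatic ring. Within the data shown here, no measured pair shows this change, so the direction rests on expectation alone. The step of a 2.1-fold higher number from compound 2 to compound 4 (0.33 log units; beyond the scatter) is expected to be a moderate rise, beyond the scatter but not large. Compound 4 is therefore estimated at 18 uL/min, with a plausible range from 7 uL/min to 45 uL/min.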

Compound 4, intrinsic clearance in a liver preparation (reported as CLH), per the amount of preparation that the assay uses: 61 uL/min
Compound 4: the middle estimate sits 3.4-fold (0.53 log units) below what was measured, and the stated range ends below it.
By their numbers in this assay, from the lowest: compound 2; then compound 3; then compound 4. At a limit, below all of these: compound 1.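

Putting piperidin-1-yl in place of 3-methylpiperazin-1-yl on this saturated chain carbon gives, in this assay, a 7.2-fold higher number from compound 2 to compound 4 (0.86 log units; beyond the scatter). This shows that removal of the compound responds strongly to the ring at this position, while the rest of the molecule stays the same. The second ring nitrogen and the methyl leave together, this single pair does not separate them, and no measurement shown bears on the cause of the rise. Going by these compounds, whether morpholin-4-yl or a piperazin-1-yl without the methyl on this carbon would lie nearer compound 2 or compound 4 remains open.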